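Chloro to Bromo in a Phenylurea Series on Rice

The source may report more compounds than this note shows. Statements on the series, on what has been measured and on what is new or still open speak of the compounds shown alone.

Three compounds have been measured in an ADME assay on the whole organism with Oryza sativa as the target, tested at 0.1 uM; a lower number here means a stronger effect, a higher number a weaker effect of the compound at the concentration tested:

compound 1, `C[C@H](NC(=O)Nc1ccccc1Cl)c1ccccc1`, 99%
compound 2, `C[C@@H](NC(=O)Nc1cccc(Cl)c1)c1ccccc1`, 97%
compound 3, `C[C@H](NC(=O)Nc1ccccc1Br)c1ccccc1`, 101%

Compound 3 differs from compound 1 by one change, (bromo in place of chloro on an aromatic carbon), and the measured step is a number 2 percentage points higher from compound 1 to compound 3 (within the scatter). Compound 2 has the same atoms as compound 1, joined differently; the difference between the two cores is not broken down here. Its value sits nearest to that of compound 1 and furthest from that of compound 3, all three within the scatter of one another.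

Compound 4, `C[C@@H](NC(=O)Nc1cccc(Br)c1)c1ccccc1`, has not yet been measured in this assay. It differs from compound 2 by bromo in place of chloro on an aromatic carbon. This is the same kind of change as that from compound 1 to compound 3, but the place is not identical: there the bromo stands ortho to a large group, here meta to a large group. The step is expected to be a number 2 percentage points higher from compound 2 to compound 4 (within the scatter), resting on the measured a number 2 percentage points higher from compound 1 to compound 3 (within the scatter). Compound 4 is therefore estimated to give 99%, between 90% and 106%.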

Compound 4, a percentage reported as activity, at one concentration (the size of the read-out at that concentration, not a potency): 100%
For compound 4 the middle estimate is 1 percentage points below the measured one; measured number inside the range.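

In this assay, bromo in place of chloro on an aromatic carbon gives a number 3 percentage points higher from compound 2 to compound 4 (within the scatter), and the change can now be compared on two cores: the same change on two cores in this assay, a number 2 percentage points higher (within the scatter) from compound 1 to compound 3 and a number 3 percentage points higher (within the scatter) from compound 2 to compound 4, 1 percentage points apart, within the scatter of two such steps. The swap therefore carries from the core of compound 1 to the core of compound 2 with steps that cannot be told apart, at the one concentration tested. It does not show that the swap would behave the same way on other cores in the series, and since both steps lie within the scatter, the agreement is between two small steps and says little about what would happen where the change had a clear effect.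

The compounds shown leave open whether a different group in place of the halogen, such as a methoxy, a nitrile or a trifluoromethyl, would move the number beyond the scatter. They also leave open what an amine or a longer chain elsewhere on the shared core would do.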